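The source may report more compounds than this note shows. Statements on the series, on what has been measured and on what is new or still open speak of the compounds shown alone.

Measured compounds in the series:

compound 1 `NNc1nonc1/C(=N/O)Nc1ccc(F)c(Br)c1` — 108 nM in an assay on isolated protein for inhibition of Indoleamine 2,3-dioxygenase 1 (Homo sapiens), read by fluorescence, with a stated time of 60 min; on this read-out lower numbers stand for stronger inhibition and higher numbers for weaker inhibition
compound 2 `O=S(=O)(CCNc1nonc1/C(=N/O)Nc1ccc(F)c(Br)c1)N1CCC1` — 191 nM in this assay

On these two numbers compound 2 gives the higher one, but only by a 1.8-fold higher number from compound 1 to compound 2 (0.25 log units; within the scatter), so the two compounds sit together within the scatter and neither is read as the stronger. Among the measured compounds shown here, that single measured step exchanges amino for 2-((azetidin-1-yl)sulfonyl)ethyl on a nitrogen of the shared core and is the only comparison available.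

Compound 3 `C#CCNS(=O)(=O)CCNc1nonc1/C(=N/O)Nc1ccc(F)c(Br)c1` keeps the whole of compound 2 apart from one exchange at the far end of that chain: propargylamino in place of azetidin-1-yl on a sulfonyl sulfur. For the measured compounds named here, no measured step in the set touches this sulfonyl substituent; the step from compound 1 to compound 2, which built the entire chain, stayed within the scatter, and a swap confined to its terminal group has no precedent here to read from. The expectation for compound 3 in this assay is therefore no shift beyond the scatter, a 1.0-fold higher number from compound 2 to compound 3 (0.02 log units; within the scatter). Compound 3 is estimated at 200 nM, within a range of 80 nM to 500 nM.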

Compound 3, half-maximal inhibitory concentration: 218 nM
Compound 3: middle estimate off by 1.1-fold (0.04 log units), on the low side, and the stated range covers the measured number.
By their numbers in this assay, from the lowest: compounds 1, 2 and 3 (each within the scatter of the next, the first and the last beyond it).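

In this assay, among the compounds shown here, this is the first look at the group on the sulfonyl sulfur, and the exchange of azetidin-1-yl for propargylamino gives a 1.1-fold higher number from compound 2 to compound 3 (0.06 log units; within the scatter), so losing the four-membered ring and gaining a triple bond and a hydrogen-bond donor leaves the number unmoved within the scatter. For the compounds shown here, the full chain now gives a first step that clears the scatter, though only modestly, with a 2.0-fold higher number from compound 1 to compound 3 (0.31 log units; beyond the scatter), whereas the azetidine-capped chain stayed inside it; compound 2 and compound 3 still cannot be told apart, so this gap does not separate the two chain ends. Nothing measured here speaks to the reason for either step.

On these data alone, both groups compared on the sulfonyl sulfur carry 4 heavy atoms, so it remains open whether a plain amino group or a larger benzylamino or morpholin-4-yl group there would also stay within the scatter. Also open, as far as these compounds go, is whether a longer chain in place of the ethyl link, or a carboxylic acid at the chain end in place of the sulfonyl group, would hold the number near these values.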